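Swapping Fluoro for Nitro: From Compound 2 to Compound 3

A few compounds are considered here, and "the series" means these few. Any claim that something is new, unique, unknown or untested is made for them only; others in the source may bear on it.

Measured in a functional assay on B16-F10 cells (Mus musculus) for antiproliferative activity, read by ELISA and MTT assay, with a stated time of 48 h; a higher number here means a weaker inhibitor, a lower number a stronger inhibitor:
compound 1, `O=C(/C=C/c1ccc(F)cc1)NS(=O)(=O)c1ccccc1`, gives 2.1 ug/mL
compound 2, `O=C(/C=C/c1ccc(F)cc1)NS(=O)(=O)c1ccc(Cl)cc1`, gives 2.6 ug/mL

Going by the values given here, compound 2 gives the higher of the two numbers so far, but the only step measured, a 1.2-fold higher number from compound 1 to compound 2 (0.09 log units; within the scatter), lies within the scatter, so compound 1 and compound 2 cannot be told apart on these data.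

Compound 3, `O=C(/C=C/c1ccc([N+](=O)[O-])cc1)NS(=O)(=O)c1ccc(Cl)cc1`, differs from compound 2 in one place: nitro in place of fluoro on an aromatic carbon. Among the compounds with values here, that change sits on the ring carrying the fluoro in compound 2, while the one measured step, a 1.2-fold higher number from compound 1 to compound 2 (0.09 log units; within the scatter), concerns the other ring and a different pair of groups, hydrogen and chloro. Within the data shown here, no measured step tests nitro against fluoro, so nothing here predicts a shift in either direction. Among the measured compounds shown here, the one step available was small, which is the only guide to how far a single change on one ring moves the number in this assay. Compound 3 is therefore expected to land close to compound 2, with the estimated step of no change at the digits printed from compound 2 to compound 3 (within the scatter) not exceeding the scatter. The estimate for compound 3 in this assay is 2.6 ug/mL, within a range from 1.2 ug/mL to 6 ug/mL.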

Compound 3, half-maximal inhibitory concentration: 13.7 ug/mL
For compound 3 the middle estimate is 5.3-fold (0.72 log units) below the measured one, outside the stated range (above it).
By their numbers in this assay, from the lowest: compounds 1 and 2 (each within the scatter of the next); then compound 3.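

In this assay, the position para to a large group proves sensitive to what sits on it: nitro in place of fluoro brings a 5.3-fold higher number from compound 2 to compound 3 (0.72 log units; beyond the scatter), so compound 3 is the weaker inhibitor of that pair. Going by these compounds alone, the earlier change on the other ring, a 1.2-fold higher number from compound 1 to compound 2 (0.09 log units; within the scatter), could not be told apart from the scatter, which makes this the first single change here with a readable effect on the number. The swap alters the heavy atoms and the hydrogen-bond acceptors at once, and no measurement is available that explains the shift.

On these data alone, with only fluoro and nitro compared at this position, it remains open whether an amine or a carboxylic acid there would give a number closer to that of compound 2 or that of compound 3. Also open, as far as these compounds go, is whether nitro in place of fluoro would have a similar effect on the core of compound 1, which carries hydrogen rather than chloro on the other ring.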